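A few compounds are considered here, and "the series" means these few. Any claim that something is new, unique, unknown or untested is made for them only; others in the source may bear on it.

In an ADME assay on microsomes from liver (Homo sapiens) for metabolic stability, read by LC-MS, using NADPH, with a stated time of 30 min, tested at 0.1 uM (a lower number here means that less of the compound is left, a higher number that more of the compound is left), compound 2 `COc1cnc(C(=O)Nc2ccc(F)c([C@]3(C)C=C(CF)OC(N)=N3)c2)cn1` gives 80%, and compound 1 `C[C@@]1(c2cc(NC(=O)c3ccc(C#N)cn3)ccc2F)C=C(CF)OC(N)=N1` gives 88%, so these two numbers cannot be told apart. Compound 3 `C[C@@]1(c2cc(NC(=O)c3coc(CF)n3)ccc2F)C=C(CF)OC(N)=N1` keeps the shared core and changes only the group on the carbonyl carbon: 2-(fluoromethyl)-1,3-oxazol-4-yl in place of 5-methoxypyrazin-2-yl on a carbonyl carbon. Among the compounds with values here, the one measured step at this place is a number 8 percentage points lower from compound 1 to compound 2 (within the scatter). That single step stayed small, but neither of its groups is a 2-(fluoromethyl)-1,3-oxazol-4-yl, so it offers only weak guidance. The expected step is therefore no larger than the scatter, with an estimate of a number 2 percentage points lower from compound 2 to compound 3 (within the scatter). For compound 3 the estimated value is 78%, with an expected range of 60% to 92%.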

Compound 3, percent of the compound remaining: 76%
Beside the measured number, compound 3's estimate is 2 percentage points above it; low and high end bracket the measured number.
By their numbers in this assay, from the lowest: compounds 3, 2 and 1 (each within the scatter of the next, the first and the last beyond it).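

In this assay the 2-(fluoromethyl)-1,3-oxazol-4-yl group gives a number 4 percentage points lower from compound 2 to compound 3 (within the scatter) and a number 12 percentage points lower from compound 1 to compound 3 (beyond the scatter) on the same carbonyl carbon. Within the data shown here, this is the first step at this position to pass beyond the scatter, and it is only modest, so a five-membered aromatic ring can stand here with much of the compound still left. No measurement shown gives a reason for this step. Still open, on these data alone, is whether the ring or its fluoromethyl group accounts for the step, and what a phenyl ring or a longer alkyl chain on this carbonyl carbon would give.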